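The source may report more compounds than this note shows. Statements on the series, on what has been measured and on what is new or still open speak of the compounds shown alone.

- compound 1 `Cc1nc(N2CCN(C)CC2)c2nc(-c3ccccc3C(F)(F)F)n(C3CCOCC3)c2n1`: 38%
- compound 2 `COc1cccc(-c2nc3c(N4CCN(C)CC4)nc(C)nc3n2C2CCOCC2)c1`: 30%
- compound 3 `Cc1nc(N2CCN(C)CC2)c2nc(-c3ccccc3F)n(C3CCOCC3)c2n1`: 30%

In an ADME assay (liver) for metabolic stability, with Liver microsome (Rattus norvegicus) as the target, read by LC-MS, using microsomes, with a stated time of 30 min, tested at 4 uM (on this read-out lower numbers stand for a less stable compound and higher numbers for a more stable compound), compound 3 gives 30%, the same number as compound 2 at the digits shown, and all three numbers lie within the usual scatter of one another.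

The next compound, compound 4 `Cc1nc(N2CCN(C)CC2)c2nc(-c3ccccc3C3CC3)n(C3CCOCC3)c2n1`, differs from compound 3 in one place: cyclopropyl in place of fluoro on an aromatic carbon. In words, this is cyclopropyl in place of fluoro on an aromatic carbon, ortho to a large group.

The closest measured change swaps fluoro for trifluoromethyl, and it shows a number 8 percentage points lower from compound 1 to compound 3 (within the scatter). The two changes involving the 3-methoxyphenyl compound show a number 8 percentage points lower from compound 1 to compound 2 (within the scatter) and no change at the digits printed from compound 2 to compound 3 (within the scatter). None of these steps rises above the scatter, so no clear step is expected in this assay. Within the data shown here, still, no measured compound carries cyclopropyl, which leaves the range wide.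

The estimated step is a number 2 percentage points higher from compound 3 to compound 4 (within the scatter), with no direction expected beyond the scatter.

The estimate for compound 4 is 32%, within an expected range of 18% to 47%.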

Compound 4, percent of the compound remaining: 67%
For compound 4 the middle estimate is 35 percentage points below the measured one; measured number outside the range, above it.
By their numbers in this assay, from the lowest: compounds 2, 3 and 1 (each within the scatter of the next); then compound 4.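

Among the earlier compounds, changing the aromatic group left the read-out in this assay within the scatter, which gave no sign that this position could matter; compound 4 shows that it can. Cyclopropyl in place of fluoro gives a large rise (a number 37 percentage points higher from compound 3 to compound 4 (beyond the scatter)), and 2-cyclopropylphenyl in place of 3-methoxyphenyl gives another (a number 37 percentage points higher from compound 2 to compound 4 (beyond the scatter)), while the modest step from trifluoromethyl (a number 29 percentage points higher from compound 1 to compound 4 (beyond the scatter)) is also beyond the scatter, leaving compound 4 apart from the other three. Nothing measured here explains this gain.

From the compounds shown here alone, only compound 4 carries cyclopropyl, so it remains open whether the gain belongs to this three-membered ring or would appear with other carbon groups. An isopropyl or cyclobutyl group in the same place would help separate these two possibilities.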